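This account rests on a few compounds, and the source may have more. Where it says the series, first, only, none or still open, it means among the compounds named here.

Working notes on the series.

Among the measured compounds shown here, compound 1 `Nc1ncnc2c1ncn2[C@@H]1O[C@H](COP(=O)(O)OP(=O)(O)O)[C@H]2O[C@@H](Cc3ccccc3)O[C@H]21` stands at the top of the two numbers so far: in an in vitro functional assay on cells for agonist activity at P2Y purinoceptor 2 (Homo sapiens), read by calcium flux (on this read-out higher numbers stand for an effect only at larger amounts of compound and lower numbers for an effect already at smaller amounts), compound 1 gives 13900 nM. For the measured compounds named here, the only other measured member, compound 2 `O=c1ccn([C@@H]2O[C@H](COP(=O)(O)OP(=O)(O)OP(=O)(O)OP(=O)(O)OC[C@@H]3O[C@H](n4ccc(=O)[nH]c4=O)[C@@H](O)[C@H]3O)[C@@H]3OC(Cc4ccccc4)O[C@H]32)c(=O)[nH]1`, is a dinucleotide built on the same benzylidene-protected sugar but carrying a tetraphosphate bridge and two pyrimidine bases; in this assay compound 2 gives 94 nM, a gap from compound 1 that lies well beyond the scatter. Going by the values given here, no single-point step between measured compounds is available, and compound 2 differs from compound 1 in several places at once, so its number says nothing direct about substitution on the purine.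

The step to compound 3 `O=C(Nc1ccccc1)Nc1ncnc2c1ncn2[C@@H]1O[C@H](COP(=O)(O)OP(=O)(O)O)[C@H]2O[C@@H](Cc3ccccc3)O[C@H]21` keeps the diphosphate and the shared core of compound 1 and alters one point: phenylcarbamoyl in place of hydrogen on a nitrogen on an aromatic ring. The change adds a single substituent to the exocyclic amine of the purine. Nothing measured in the series reports on a substituent at this position, so the direction of the step is open; a step of modest size in either direction, or none beyond the scatter, is expected a 1.5-fold lower number from compound 1 to compound 3 (0.19 log units; within the scatter). For compound 3 in this assay the estimate is 9000 nM, with a range from 2000 nM to 40000 nM.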

Compound 3, half-maximal effective concentration: 13900 nM
Estimate against measurement, compound 3: 1.5-fold (0.19 log units) below; the range from low to high includes it.
By their numbers in this assay, from the lowest: compound 2; then compounds 1 and 3 (each within the scatter of the next).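

In this assay, among the compounds shown here, this is the first reading on a substituent at this position: phenylcarbamoyl in place of hydrogen on a nitrogen on an aromatic ring gives no change at the digits printed from compound 1 to compound 3 (within the scatter) and stays within the scatter. The amino to (phenylcarbamoyl)amino change therefore brings in nine heavy atoms, including a six-membered aromatic ring of carbon only, with no shift in the number, so this position can carry a group of this kind on the shared core of compound 1 without a measurable step in either direction. Nothing at hand gives a reason for this flat result.

Going by these compounds, a single substituent cannot show whether the result holds across the position, so it remains open whether an acetyl, a methyl or a benzyl group on the same nitrogen would also leave the number in place, or whether a carboxylic acid on the phenyl ring would move it. On these data alone, it also remains open whether phenylcarbamoyl would give the same flat step on a compound carrying a triphosphate in place of the diphosphate.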